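Adding Dimethylamino to Compound 1: What Dose to Expect

The source may hold more compounds than are shown below. What is called first, only, known or untested is meant among the compounds shown, and "the series" means these compounds.

Compound 1 `O=C(N/N=C/c1ccccc1)Nc1cccc2ccccc12` was tested in a functional assay on the whole organism (strain Swiss albino) with Mus musculus as the target, in the maximal electroshock model, with a stated time of 0.5 h (a higher number here means that more compound is needed for the effect, a lower number that less compound is needed), where compound 1 gives 300 mg/kg. A close relative, compound 2 `C/C(=N\NC(=O)Nc1cccc2ccccc12)c1ccccc1`, gives 300 mg/kg in this assay. These two values are level at the digits shown and sit within the usual scatter of each other, so compound 1 stands alongside compound 2 with no difference worth reading into. Compound 3 `CN(C)c1ccc(/C=N/NC(=O)Nc2cccc3ccccc23)cc1` has not yet been measured. It differs from compound 1 in one place: dimethylamino in place of hydrogen on an aromatic carbon. Among the compounds with values here, no measured pair in this set carries the same change, so nothing here shows how large a step such an addition brings, and the two measured values offer no hint that the dose moves much. The expected step of no change at the digits printed from compound 1 to compound 3 (within the scatter) is therefore none beyond the scatter. The estimate for compound 3 is 300 mg/kg, with a range from 100 mg/kg to 600 mg/kg.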

Compound 3, minimum effective dose: 100 mg/kg
Beside the measured number, compound 3's estimate is 3.0-fold (0.48 log units) above it, and the stated range covers the measured number.
By their numbers in this assay, from the lowest: compound 3; then compounds 1 and 2 (each within the scatter of the next).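

In this assay, placing dimethylamino on an aromatic carbon, para to a large group, gives a 3.0-fold lower number from compound 1 to compound 3 (0.48 log units; beyond the scatter) and moves the number beyond the scatter. Within the data shown here, compound 1 and compound 2 sat level and gave no sign of such a shift, so this is the first indication that this position of the shared core can alter the dose needed. Nothing available here speaks to the reason for the step.

From the compounds shown here alone, whether the lower number is specific to dimethylamino or would also follow from another group at this place, such as a plain amine, a methoxy group or a chlorine atom, remains open. So does whether the same addition would bring a similar step on compound 2, since this change has been seen only once.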